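The source may hold more compounds than are shown below. What is called first, only, known or untested is meant among the compounds shown, and "the series" means these compounds.

Values in a functional assay for inhibition, with Homo sapiens as the target (on this read-out higher numbers stand for weaker inhibition and lower numbers for stronger inhibition), for the three measured compounds:
- compound 1 (`COc1ccc(-c2nc(-c3ccc4c(c3)CCC(=O)N4)cs2)cc1OC`) gives 300 nM
- compound 2 (`COc1ccc(-c2nc(-c3ccc4c(c3)CCC(=O)N4)cs2)cc1`) gives 9000 nM
- compound 3 (`CCOc1ccc(-c2nc(-c3ccc4c(c3)CCC(=O)N4)cs2)cc1OCC`) gives 80 nM

Compound 3 has the lowest of these three numbers, with compound 1 nearest to it and compound 2 furthest away. The next compound, compound 4 (`CCOc1cc(-c2nc(-c3ccc4c(c3)CCC(=O)N4)cs2)ccc1OC`), has not been measured. It differs from compound 3 in one place (hydrogen in place of methyl on a saturated chain carbon bound to an oxygen on an aromatic ring), with hydrogen in place of methyl on a saturated chain carbon bound to an oxygen on an aromatic ring, so one ethoxy becomes methoxy. Compound 4 therefore carries one ethoxy and one methoxy, whereas compound 3 has two ethoxy groups and compound 1 has two methoxy groups.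

For the measured compounds named here, the only measured single-place step, a 30-fold higher number from compound 1 to compound 2 (1.48 log units; beyond the scatter), removes a whole methoxy. It shows that the number can move far when such a group is lost, but it is a much larger change than trimming one methyl. The better guide is the gap between compound 3 at 80 nM and compound 1 at 300 nM, since those two differ at both groups and compound 4 changes only one. A number between them is expected, so the expected size and direction are a 2.0-fold higher number from compound 3 to compound 4 (0.30 log units; within the scatter) in this assay overall. For compound 4 the estimate is 160 nM, with an expected range from 70 nM to 400 nM for this measurement.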

Compound 4, half-maximal inhibitory concentration: 90 nM
Compound 4: the middle estimate sits 1.8-fold (0.25 log units) above what was measured; low and high end bracket the measured number.
By their numbers in this assay, from the lowest: compounds 3 and 4 (each within the scatter of the next); then compound 1; then compound 2.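

In this assay the two groups on the aromatic ring turn out not to count alike: changing one ethoxy of compound 3 to methoxy leaves the number within the scatter (a 1.1-fold higher number from compound 3 to compound 4 (0.05 log units; within the scatter)), while adding a methyl to the other group, so that its methoxy becomes ethoxy, gives a modest but real step (a 3.3-fold lower number from compound 1 to compound 4 (0.52 log units; beyond the scatter)). That second group is the ethoxy kept in compound 4, and placing it on the bare aromatic carbon of compound 2 gives a large step (a 100-fold lower number from compound 2 to compound 4 (2.00 log units; beyond the scatter)), so among these compounds a methoxy serves as well as an ethoxy in one place but not in the other. Nothing available here explains why the two places differ.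

On these data alone, whether a longer chain such as propoxy, or an amine, would hold the number at either place remains open. So does how far the ethoxy would carry on its own, with a plain hydrogen on the aromatic carbon where compound 4 has its methoxy.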